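The source may hold more compounds than are shown below. What is called first, only, known or untested is meant among the compounds shown, and "the series" means these compounds.

Compound 1 `Cc1cc(OCc2cccc(C#N)c2)ccc1-c1cc(CN2CCN(Cc3ccc(C(F)(F)F)cc3)CC2)no1` and compound 2 `Cc1cc(-c2cc(CN3CCN(Cc4ccc(C(F)(F)F)cc4)CC3)no2)ccc1OCc1cccc(C#N)c1` share the same atoms joined differently; the difference between the two cores is not broken down here. In a functional assay on Mahlavu cells (Homo sapiens) for antiproliferative activity, read by sulforhodamine B assay, with a stated time of 72 h (a higher number here means a weaker inhibitor, a lower number a stronger inhibitor), compound 1 gives 500 nM, and compound 2 gives 450 nM, the two numbers lying within the usual scatter of each other. Compound 3 `N#Cc1cccc(COc2ccc(-c3cc(CN4CCN(Cc5ccc(C(F)(F)F)cc5)CC4)no3)c(F)c2)c1` arises from compound 1 through (fluoro in place of methyl on an aromatic carbon); in this assay compound 3 gives 400 nM, so the step is a 1.3-fold lower number from compound 1 to compound 3 (0.10 log units; within the scatter). Compound 4 `N#Cc1cccc(COc2ccc(-c3cc(CN4CCN(Cc5ccc(C(F)(F)F)cc5)CC4)no3)cc2F)c1` carries the same kind of change on the core of compound 2, (fluoro in place of methyl on an aromatic carbon), here ortho to a (3-cyanobenzyl)oxy group and meta to a large group rather than ortho to a large group and meta to a (3-cyanobenzyl)oxy group. The step to compound 4 is expected to be similar, a 1.1-fold lower number from compound 2 to compound 4 (0.05 log units; within the scatter), because a 1.3-fold lower number from compound 1 to compound 3 (0.10 log units; within the scatter) lay within the scatter. Compound 4 is therefore estimated at 400 nM, between 200 nM and 800 nM.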

Compound 4, half-maximal inhibitory concentration: 500 nM
The estimate for compound 4 lay 1.3-fold (0.10 log units) below the measured number; low and high end bracket the measured number.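

In this assay, fluoro in place of methyl on an aromatic carbon gives a 1.1-fold higher number from compound 2 to compound 4 (0.05 log units; within the scatter). Set beside the earlier step, the two cores agree: the same change on two cores in this assay, a 1.3-fold lower number (0.10 log units; within the scatter) from compound 1 to compound 3 and a 1.1-fold higher number (0.05 log units; within the scatter) from compound 2 to compound 4, 1.4-fold (0.14 log units) apart, within the scatter of two such steps. This shows that the change carried from one core to the other without a detectable difference in this assay, but with both steps inside the scatter, it shows no effect of the change on either core and cannot show how a larger step would transfer.

From the compounds shown here alone, only methyl and fluoro appear on these aromatic carbons, so it remains open whether chloro, methoxy or hydroxyl would behave alike on the two cores. Going by these compounds, whether the same holds with another group in place of the nitrile also remains open.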